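The source may report more compounds than this note shows. Statements on the series, on what has been measured and on what is new or still open speak of the compounds shown alone.

For the measured compounds named here, compound 1, with the structure `COc1cc(-c2cc(/C=C/C(=O)c3ccc(N)cc3)[nH]n2)cc(OC)c1OC`, is one of two compounds measured in a functional assay on MCF7 cells (Homo sapiens) for inhibition, read by sulforhodamine B assay, with a stated time of 48 h; on this read-out higher numbers stand for lower toxicity in this test and lower numbers for higher toxicity in this test. In this assay compound 1 gives 60500 nM, the higher of the two numbers recorded. The other measured compound, compound 2, has the structure `COc1ccc(-c2cc(/C=C/C(=O)c3ccc(OC)c(OC)c3)[nH]n2)cc1` and in this assay compound 2 gives 5110 nM; the gap between these two values lies beyond the usual scatter, so compound 2 sits clearly below compound 1 on this read-out. Going by the values given here, the two share a common core and differ in several places at once, so no single step between them can be isolated.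

Compound 3, with the structure `COc1cc(-c2cc(/C=C/C(=O)c3ccc(Cl)c(Cl)c3)[nH]n2)cc(OC)c1OC`, has not yet been measured in this assay. It is reached from compound 1 by a single change: 3,4-dichlorophenyl in place of 4-aminophenyl on a carbonyl carbon. Because compound 2 gives 5110 nM while compound 1 gives 60500 nM, the expectation is that replacing the 4-aminophenyl group lowers the number, with a step of a 4.0-fold lower number from compound 1 to compound 3 (0.61 log units; beyond the scatter) that is expected to exceed the scatter. The estimate for compound 3 in this assay is 15000 nM, expected to fall between 4000 nM and 50000 nM.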

Compound 3, concentration lethal to 50% of the cells: > 100000 nM
Compound 3 was reported as a limit; the forecaster's own chance of this, stated with the estimate: 5%; middle value at least 6.6-fold (0.82 log units) from the limit.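

In this assay, from the compounds shown here alone, compound 3 is recorded as a limit and not as a number, so its result sets only a floor: the limit of > 100000 nM in this assay, at which 1 of the 3 values shown sits. Read as a step, 3,4-dichlorophenyl in place of 4-aminophenyl on a carbonyl carbon gives an at least 1.6-fold higher number from compound 1 to compound 3 (0.21 log units; that floor lies within the scatter), so this change on the shared core brings no lowering of the number, and the true size of the step remains unknown. For the compounds shown here, this is the first view of this position alone, since compound 1 and compound 2 differ in several places at once, whereas here only this group changes, with 1 hydrogen-bond donor and 1 hydrogen-bond acceptor leaving and 0 of each entering.

The compounds shown leave open whether the result follows from losing the amine or from adding the two chlorines, since an unsubstituted phenyl, a single chlorine or a hydroxyl on that phenyl ring is not among them. They also leave open how far the same change would carry over to a core with a different set of methoxy groups, such as that of compound 2.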